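Compound 4: from 2-fluorophenyl to 2,6-difluorophenyl

The source may hold more compounds than are shown below. What is called first, only, known or untested is meant among the compounds shown, and "the series" means these compounds.

- compound 1 `O=C1Nc2ccc(F)cc2/C1=N/NC(=S)Nc1ccccc1C(F)(F)F` gives 10%
- compound 2 `O=C1Nc2ccc(F)cc2/C1=N/NC(=S)Nc1ccc(OC(F)(F)F)cc1` gives 20%
- compound 3 `O=C1Nc2ccc(F)cc2/C1=N/NC(=S)Nc1ccccc1F` gives 25%
- compound 4 `O=C1Nc2ccc(F)cc2/C1=N/NC(=S)Nc1c(F)cccc1F` is not yet measured

In a functional assay on the whole organism for inhibition, with Lemna aequinoctialis as the target, with a stated time of 7 days, tested at 50 ug/mL (on this read-out higher numbers stand for more inhibition of growth at the one concentration tested and lower numbers for less inhibition of growth), compound 3 gives 25% and compound 2 gives 20% as two values within the scatter of each other. Compound 3 stands clear of compound 1 only, with a number 15 percentage points higher from compound 1 to compound 3 (beyond the scatter) as the measured step for fluoro in place of trifluoromethyl on an aromatic carbon.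

The change now in view is fluoro in place of hydrogen on an aromatic carbon, ortho to a large group and meta to a fluoro group. It takes the 2-fluorophenyl of compound 3 to the 2,6-difluorophenyl of compound 4, and fluoro in place of hydrogen on an aromatic carbon gives the count.

Among the compounds with values here, no measured step covers this exact change. The nearest evidence is the modest a number 15 percentage points higher from compound 1 to compound 3 (beyond the scatter) on the same kind of aromatic carbon, and that step exchanges one fluorinated group for another instead of replacing a hydrogen. This gives no firm ground for a direction.

The step expected in this assay is no change at the digits printed from compound 3 to compound 4 (within the scatter) and nothing beyond the scatter is expected in either direction. Compound 4 is estimated at 25% with an expected range from 10% to 40% in this read-out.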

Compound 4, percent growth inhibition at one concentration: 10%
The estimate for compound 4 lay 15 percentage points above the measured number, within the range that was stated.
By their numbers in this assay, from the lowest: compounds 1, 4, 2 and 3 (each within the scatter of the next, the first and the last beyond it).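

In this assay the replacement of a hydrogen by fluoro gives a number 15 percentage points lower from compound 3 to compound 4 (beyond the scatter), a modest step that lies beyond the scatter. Within the data shown here, the earlier step, a number 15 percentage points higher from compound 1 to compound 3 (beyond the scatter), only exchanged one fluorinated group for another, so this result is the first to show that this aromatic carbon, ortho to a large group and meta to a fluoro group, responds when its hydrogen is replaced, and that the response is downward. Adding fluoro to the 2-fluorophenyl therefore does not raise the growth inhibition in this pair, and no measurement on these compounds bears on why the number falls.

Open, from the compounds shown here alone, is whether the fall belongs to fluoro itself or would also appear with another group on the same carbon, such as chloro, methyl, methoxy or an amine. Also open, going by these compounds, is whether fluoro in place of hydrogen on the other carbons of this ring gives a step of the same direction, since this single pair speaks for one carbon and one concentration only.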